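Adding a Methyl on the Side Chain

The compounds below may be only part of what the source reports. "The series", "measured", "known", "first", "only" and "open" are said of these compounds alone.

Measured so far:
compound 1, `COc1cc(C(=O)O)ccc1OCCCCOc1ccc(C(=O)CC(C)C)c(O)c1C`: 99%
compound 2, `CCC(=O)c1ccc(OCCCCOc2ccc(F)c(C(=O)O)c2)c(C)c1O`: 96%
compound 3, `Cc1c(OCCCCOc2ccc(F)c(C(=O)O)c2)ccc(C(=O)C(C)C)c1O`: 83%

All three were tested in an ADME assay on a cell-free system (plasma, Rattus norvegicus) for metabolic stability, read by LC-MS, with a stated time of 60 min, tested at 100 uM; on this read-out higher numbers stand for a more stable compound and lower numbers for a less stable compound. Compound 1 and compound 2 lie within the scatter of each other, so no order can be read from them. Compound 2 and compound 3 share a core and differ by methyl in place of hydrogen on a saturated chain carbon bound to a carbonyl carbon and a saturated chain carbon; this change gave a number 13 percentage points lower from compound 2 to compound 3 (beyond the scatter). The difference between the core of compound 1 and the core of compound 2 is not broken down here.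

Compound 4, `COc1cc(C(=O)O)ccc1OCCCCOc1ccc(C(=O)CC(C)(C)C)c(O)c1C`, has not been measured yet. It differs from compound 1 by methyl in place of hydrogen on a saturated chain carbon bound to three saturated chain carbons. Going by the values given here, this is the same kind of change as the one from compound 2 to compound 3, but not the same: there the methyl enters on a saturated chain carbon bound to a carbonyl carbon and a saturated chain carbon, whereas in compound 4 it enters on a saturated chain carbon bound to three saturated chain carbons.

Among the compounds with values here, compound 4 is expected to show a number 7 percentage points lower from compound 1 to compound 4 (within the scatter), a smaller step than the measured one, because a number 13 percentage points lower from compound 2 to compound 3 (beyond the scatter) is the only guide and the place of the change differs. The expected value for compound 4 in this assay is 92%, with a range from 80% to 99%.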

Compound 4, percent of the compound remaining: 48%
The estimate for compound 4 lay 44 percentage points above the measured number; the measured number lies below the stated range.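

In this assay, putting a methyl in place of a hydrogen gave a number 51 percentage points lower from compound 1 to compound 4 (beyond the scatter). Both steps point downward, but their sizes do not match, so the size of the step did not carry over from one core to the other: the same change on two cores in this assay, a number 13 percentage points lower (beyond the scatter) from compound 2 to compound 3 and a number 51 percentage points lower (beyond the scatter) from compound 1 to compound 4, 38 percentage points apart, beyond the scatter of two such steps

This does not show that the core alone sets the size of the step: the methyl also enters at a different place in each pair, on a saturated chain carbon bound to three saturated chain carbons in compound 4 and on a saturated chain carbon bound to a carbonyl carbon and a saturated chain carbon in compound 3, and these two pairs cannot separate place from core.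

Still open, from the compounds shown here alone, is how the neopentylcarbonyl compound would behave on the core of compound 2, a comparison that would help separate place from core. Also open, going by these compounds, is how this assay would read for a compound with a cyclopropyl ring in place of the neopentyl group, or with an amide in place of the carboxylic acid.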